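Adding a Methyl Group to Compound 3: an Expected Outcome

A few compounds are considered here, and "the series" means these few. Any claim that something is new, unique, unknown or untested is made for them only; others in the source may bear on it.

Compound 1 `O=[N+]([O-])c1ccc(NCc2ccccc2O)cc1`: in a functional assay on Jurkat cells (Homo sapiens) for activation, with a stated time of 24 h (a higher number here means that more compound is needed for the effect, a lower number that less compound is needed), compound 1 gives "not active" (no number reported).
Compound 2 `Oc1ccccc1CNc1ccc(N2CCNCC2)cc1`: in this assay compound 2 gives "not active" (no number reported).
Compound 3 `Oc1ccccc1CNc1ccc(-c2ccccc2)cc1`: in this assay compound 3 gives 1820 nM.

Of the three measured compounds, only compound 3 has a numerical value in this assay; compound 1 and compound 2 were reported without a single number, so nothing can be said about how they compare in size with compound 3. For the measured compounds named here, no pair of measured compounds differs in only one place, so there is no measured step that shows how a single change moves the numbers.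

Compound 4 `Cc1cccc(-c2ccc(NCc3ccccc3O)cc2)c1` differs from compound 3 in one way: methyl in place of hydrogen on an aromatic carbon. This is a small change, a methyl in place of hydrogen on an aromatic carbon. Going by the values given here, with no comparable step to lean on, the expectation is that the change stays within the usual scatter of this assay, with no clear direction. The estimate for compound 4 is 1500 nM, with a range from 500 nM to 4500 nM. That estimate means an expected step of a 1.2-fold lower number from compound 3 to compound 4 (0.08 log units; within the scatter) that does not go beyond the scatter.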

Compound 4, half-maximal effective concentration: 9190 nM
Compound 4: the middle estimate sits 6.1-fold (0.79 log units) below what was measured; measured number above the stated range.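

Going from phenyl to 3-methylphenyl gives a 5.0-fold higher number from compound 3 to compound 4 (0.70 log units; beyond the scatter) in this assay, the first step in this series that can be read as a number. It shows that a single added methyl at this place on the phenyl group is enough to move the result beyond the scatter, toward more compound being needed for the effect, so this position is sensitive to even a small addition. Nothing among the available measurements speaks to the reason for this shift.

From the compounds shown here alone, whether a fluorine atom, a methoxy group or a longer chain such as ethyl at the same place would raise the number as well, or by as much, remains open. So does whether an amine or a carboxylic acid there would push the number the other way.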